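The source may report more compounds than this note shows. Statements on the series, on what has been measured and on what is new or still open speak of the compounds shown alone.

Compound 1 `O/N=C(\CCN1CCN(c2ccccn2)CC1)c1cccc(Cl)c1`: 11.9 nM
Compound 2 `O/N=C(\CCN1CCN(c2ccccn2)CC1)c1ccc(F)cc1`: 31 nM

Within the data shown here, in a functional assay on HEK293 cells with D(4) dopamine receptor (Homo sapiens) as the target, read by FLIPR (a higher number here means that more compound is needed for the effect, a lower number that less compound is needed), compound 2 stands highest of the two numbers, with compound 1 as its only neighbour. That single measured step reads a 2.6-fold higher number from compound 1 to compound 2 (0.42 log units; beyond the scatter), a modest change from swapping one ring substituent for another. Compound 3 `O/N=C(\CCN1CCN(c2ccccn2)CC1)c1ccc(F)cc1F` differs from compound 2 by fluoro in place of hydrogen on an aromatic carbon. Among the measured compounds shown here, no measured step adds a second fluoro to a ring already carrying one, so the only guide is that the one known substituent change was modest. For compound 3 the expected step is therefore small, a 1.2-fold lower number from compound 2 to compound 3 (0.09 log units; within the scatter), with no direction claimed beyond the scatter. Compound 3 is estimated at 25 nM, within 8 nM to 80 nM.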

Compound 3, half-maximal effective concentration: 8.9 nM
Compound 3: the middle estimate sits 2.8-fold (0.45 log units) above what was measured; measured number inside the range.
By their numbers in this assay, from the lowest: compounds 3 and 1 (each within the scatter of the next); then compound 2.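

In this assay, fluoro in place of hydrogen on the aromatic carbon ortho to a large group gives a 3.5-fold lower number from compound 2 to compound 3 (0.54 log units; beyond the scatter), so this ring position responds to a single added fluorine atom. The second fluoro also closes the gap to the 3-chlorophenyl compound, leaving a 1.3-fold lower number from compound 1 to compound 3 (0.13 log units; within the scatter). Nothing shown gives a reason for this step.

Still open, going by these compounds, is whether 2-fluorophenyl, without the 4-fluoro group, would show the same effect. Also open, on these data alone, is how a methyl, a methoxy or an amine would behave at this place.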